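Replacing Nitro with Fluoro in Compound 3

The source may report more compounds than this note shows. Statements on the series, on what has been measured and on what is new or still open speak of the compounds shown alone.

Compounds measured so far in a functional assay on PC-3 cells (Homo sapiens) for cytotoxicity, read by MTT assay, with a stated time of 72 h (on this read-out lower numbers stand for stronger inhibition and higher numbers for weaker inhibition), are these three.
Compound 1 `CNC(=O)c1cc(Oc2ccc(C(=O)/C=C/c3ccco3)cc2)ccn1` gives "not determined" (no result reported)
Compound 2 `CNC(=O)c1cc(Oc2ccc(C(=O)/C=C/c3ccc(Br)cc3)cc2)ccn1` gives 18500 nM
Compound 3 `CNC(=O)c1cc(Oc2ccc(C(=O)/C=C/c3ccc([N+](=O)[O-])cc3)cc2)ccn1` gives 11100 nM

Among the measured compounds shown here, compound 3 has only one numerical neighbour, compound 2, and the two cannot be told apart, since their gap lies within the scatter of repeated measurements. Compound 1 offers no number to compare.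

The next molecule is compound 4 `CNC(=O)c1cc(Oc2ccc(C(=O)/C=C/c3ccc(F)cc3)cc2)ccn1`, which carries fluoro in place of nitro on an aromatic carbon, para to a large group fluoro in place of nitro on an aromatic carbon in the same shared core.

For the measured compounds named here, only one measured step bears on this change, at the same place on the molecule: a 1.7-fold lower number from compound 2 to compound 3 (0.22 log units; within the scatter) when nitro replaced bromo. That single step stayed within the scatter, although it says nothing directly about fluoro. In this assay, then, no step beyond the scatter is expected, and no direction can be favoured with confidence.

The estimated step is a 1.3-fold higher number from compound 3 to compound 4 (0.10 log units; within the scatter), which would stay within the scatter. For compound 4 the expected value is 14000 nM, with an estimated range from 6000 nM to 32000 nM as the likely span.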

Compound 4, half-maximal inhibitory concentration: 6140 nM
Compound 4: middle estimate off by 2.3-fold (0.36 log units), on the high side, and the stated range covers the measured number.
By their numbers in this assay, from the lowest: compounds 4, 3 and 2 (each within the scatter of the next, the first and the last beyond it).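

At this position, para to a large group, this assay now shows a step beyond the scatter: fluoro in place of bromo gives a 3.0-fold lower number from compound 2 to compound 4 (0.48 log units; beyond the scatter), so changing this group can shift the number modestly. Fluoro in place of nitro gives a 1.8-fold lower number from compound 3 to compound 4 (0.26 log units; within the scatter), which leaves compound 3 and compound 4 indistinguishable, even though nitro has three heavy atoms and fluoro only one. No measurement is available to explain either step.

With only bromo, nitro and fluoro compared here, the compounds shown leave open what an amine, a methoxy group or a carboxylic acid would do at this position. On these data alone, it is also open whether the gap between compound 2 and compound 4 would hold on other cell types.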